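Notes on a cyano analogue of compound 1

This account rests on a few compounds, and the source may have more. Where it says the series, first, only, none or still open, it means among the compounds named here.

Among the compounds with values here, compound 1 `COc1ccc(C(=O)Nc2cccc(-c3oc4cc(-c5ccc(F)cc5)ccc4c(=O)c3O)c2)cc1` is the weakest of the three compounds measured so far: in a functional assay on MDA-MB-231 cells (Homo sapiens) for antiproliferative activity, read by CCK-8 assay, with a stated time of 72 h (on this read-out lower numbers stand for stronger inhibition and higher numbers for weaker inhibition), compound 1 gives 16500 nM, and its steps to both other compounds lie beyond the scatter. Compound 2 `Cc1cccc(C(=O)Nc2cccc(-c3oc4cc(-c5ccc(F)cc5)ccc4c(=O)c3O)c2)c1` gives 2840 nM in this assay, and compound 3 `Cc1cc(C(=O)Nc2cccc(-c3oc4cc(-c5ccc(F)cc5)ccc4c(=O)c3O)c2)ccc1F` gives 7440 nM. Both measured steps away from compound 1 lower the number: a 5.8-fold lower number from compound 1 to compound 2 (0.76 log units; beyond the scatter) and a 2.2-fold lower number from compound 1 to compound 3 (0.35 log units; beyond the scatter). Between the two lower compounds, a 2.6-fold higher number from compound 2 to compound 3 (0.42 log units; beyond the scatter).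

Compound 4 `N#Cc1ccc(C(=O)Nc2cccc(-c3oc4cc(-c5ccc(F)cc5)ccc4c(=O)c3O)c2)cc1` differs from compound 1 by cyano in place of methoxy on an aromatic carbon. Within the data shown here, no measured step covers this exact change. The two steps that bear on it both replace the 4-methoxyphenyl of compound 1 with another aryl group on the carbonyl carbon, and both lower the number by a modest amount. A modest lowering is therefore expected here as well, in the same direction, while the size remains uncertain since cyano has not been measured in this series. Compound 4 is expected to give 7000 nM in this assay, with a range from 2500 nM to 20000 nM. This estimate means a 2.4-fold lower number from compound 1 to compound 4 (0.37 log units; beyond the scatter).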

Compound 4, half-maximal inhibitory concentration: 11600 nM
For compound 4 the middle estimate is 1.7-fold (0.22 log units) below the measured one, within the range that was stated.
By their numbers in this assay, from the lowest: compound 2; then compounds 3, 4 and 1 (each within the scatter of the next, the first and the last beyond it).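

In this assay, cyano in place of methoxy on this aromatic carbon, para to a large group, gives a result within the scatter (a 1.4-fold lower number from compound 1 to compound 4 (0.15 log units; within the scatter)). The 4-cyanophenyl group also stays within the scatter of the 4-fluoro-3-methylphenyl group (a 1.6-fold higher number from compound 3 to compound 4 (0.19 log units; within the scatter)), whereas the 3-methylphenyl group remains clearly separate (a 4.1-fold higher number from compound 2 to compound 4 (0.61 log units; beyond the scatter)), so compound 2 alone stands beyond the scatter of all three other compounds. No measured data available here explain these differences.

Going by these compounds, it remains open whether the number for compound 2 depends on the methyl group itself or on where it sits on the ring. Also open, on these data alone, is how an amine or a carboxylic acid in place of methoxy at this position would read in this assay.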